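The source may report more compounds than this note shows. Statements on the series, on what has been measured and on what is new or still open speak of the compounds shown alone.

In an ADME assay on HEK293 cells (Homo sapiens) for cytotoxicity, with a stated time of 6 h (a lower number here means that less compound is tolerated, a higher number that more compound is tolerated), compound 1 `CCCCNc1nc(N)nc2ccc(CO)cc12` gives > 18000 nM, which is a limit of the assay and not a number. Compound 2 `CCCCNc1nc(N)nc2ccc(CCc3ccc(N(C)C)cc3)cc12` gives > 18000 nM, again a limit. Compound 2 therefore stands at the limit of > 18000 nM in this assay, at which 2 of the 2 values shown sit. Compound 3 `CCCCNc1nc(N)nc2ccc(CCc3ccccn3)cc12` has pyridin-2-yl in place of 4-(dimethylamino)phenyl on a saturated chain carbon, two bonds along the chain from an aromatic carbon. Among the compounds with values here, no measured step shows what such a change does, and no change beyond the scatter, in either direction, is expected in this assay. The expected step that the limit leaves unreadable from compound 2 to compound 3 is an estimate only. For compound 3 the estimate is 20000 nM, with an expected range of 10000 nM to 40000 nM.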

Compound 3, half-maximal cytotoxic concentration: > 18000 nM
Compound 3: no number, only a limit (the forecaster's own chance of this, stated with the estimate: 80%); the middle value does not contradict the limit.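

Within the data shown here, compound 1, compound 2 and compound 3 each give only a limit in this assay, so no step among them can be read: the limit of > 18000 nM in this assay, at which 3 of the 3 values shown sit. The compounds shown leave open whether either change alters cytotoxicity at all.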